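Diethylamino in place of dimethylamino: stability notes

A few compounds are considered here, and "the series" means these few. Any claim that something is new, unique, unknown or untested is made for them only; others in the source may bear on it.

Measured in an ADME assay on microsomes from liver (Mus musculus) for metabolic stability, using NADPH, with a stated time of 10 min (on this read-out lower numbers stand for a less stable compound and higher numbers for a more stable compound), so far:
- compound 1 `NC/C=C\CN(C[C@H]1Cc2ncccc2CN1)[C@H]1CCCc2cccnc21` gives 37%
- compound 2 `NC(=O)NCCCCN(C[C@H]1Cc2ncccc2CN1)[C@H]1CCCc2cccnc21` gives 32%
- compound 3 `CN(C)CCCCN(C[C@H]1Cc2ncccc2CN1)[C@H]1CCCc2cccnc21` gives 55%

Compound 3 at 55% stands highest of the three, and its gaps to both others lie beyond the scatter. The change to compound 4 `CCN(CC)CCCCN(C[C@H]1Cc2ncccc2CN1)[C@H]1CCCc2cccnc21` is diethylamino in place of dimethylamino on a saturated chain carbon, four bonds along the chain from an amine nitrogen and reads as diethylamino in place of dimethylamino on a saturated chain carbon, four bonds along the chain from an amine nitrogen.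

The closest measured evidence is a number 23 percentage points higher from compound 2 to compound 3 (beyond the scatter) at that same place, with dimethylamino in place of ureido. Next comes a number 18 percentage points higher from compound 1 to compound 3 (beyond the scatter) with 3-(dimethylamino)propyl in place of 3-aminoprop-1-en-1-yl. Both steps are modest, and both replace a more different group than the one now proposed. For the measured compounds named here, no measured step goes from dimethylamino to diethylamino, so the direction remains tentative. The step expected is a number 5 percentage points lower from compound 3 to compound 4 (within the scatter) and nothing beyond the scatter is expected. In this assay the estimate for compound 4 is 50% running from 33% to 66% as the expected range.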

Compound 4, percent of the compound remaining: 1%
Compound 4: middle estimate off by 49 percentage points, on the high side; measured number outside the range, below it.
By their numbers in this assay, from the lowest: compound 4; then compounds 2 and 1 (each within the scatter of the next); then compound 3.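

In this assay, for the compounds shown here, the end of the chain, on a saturated chain carbon four bonds along the chain from an amine nitrogen, proves far less tolerant than the earlier compounds showed: diethylamino in place of dimethylamino gives the largest step so far (a number 54 percentage points lower from compound 3 to compound 4 (beyond the scatter)), although the counted donors and acceptors stay the same and no ring enters. A dialkylamino end group therefore does not by itself carry the stability of compound 3, since diethylamino also ends up under the ureido group (a number 31 percentage points lower from compound 2 to compound 4 (beyond the scatter)) and the 3-(diethylamino)propyl chain under the 3-aminoprop-1-en-1-yl chain (a number 36 percentage points lower from compound 1 to compound 4 (beyond the scatter)). No measurement available here bears on what lies behind this drop.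

Still open, on these data alone, is whether the loss grows step by step with the groups on the terminal nitrogen, which an ethylmethylamino group at the same place would help to settle. Also open, as far as these compounds go, is whether the drop persists when the two ethyl groups are tied back into a pyrrolidine ring, or when diethylamino sits on a shorter chain.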